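Aminophenyl Replacing Catechol in a Trimethoxychalcone Series

The source may hold more compounds than are shown below. What is called first, only, known or untested is meant among the compounds shown, and "the series" means these compounds.

Compound 1 `COc1cc(OC)c(C(=O)/C=C/c2ccc(O)c(O)c2)c(OC)c1` and compound 2 `COc1cc(OC)c(C(=O)/C=C/c2ccc(O)c(OC)c2)c(OC)c1` share a core and differ only in a methyl in place of hydrogen on an oxygen on an aromatic ring. In a functional assay on HepG2 cells (Homo sapiens) for inhibition, read by MTT assay, with a stated time of 72 h (on this read-out lower numbers stand for stronger inhibition and higher numbers for weaker inhibition), compound 1 gives 27500 nM, and compound 2 gives 17000 nM. Within the data shown here, compound 1 thus has the highest of the two numbers, and the only recorded step, a 1.6-fold lower number from compound 1 to compound 2 (0.21 log units; within the scatter), is within the scatter. Compound 3 `COc1cc(OC)c(C(=O)/C=C/c2ccc(N)cc2)c(OC)c1` is the unmeasured member: 4-aminophenyl in place of 3,4-dihydroxyphenyl on a double-bonded chain carbon bound to a double-bonded chain carbon. Among the measured compounds shown here, no measured step touches the 4-aminophenyl, so the expectation for compound 3 can rest only on the fact that the single change seen so far, a 1.6-fold lower number from compound 1 to compound 2 (0.21 log units; within the scatter), stayed within the scatter. Compound 3 is therefore expected to give about 20000 nM in this assay, with a range of 6000 nM to 60000 nM. The step this implies, a 1.4-fold lower number from compound 1 to compound 3 (0.14 log units; within the scatter), is expected to lie within the scatter.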

Compound 3, half-maximal inhibitory concentration: 45200 nM
For compound 3 the middle estimate is 2.3-fold (0.35 log units) below the measured one; low and high end bracket the measured number.
By their numbers in this assay, from the lowest: compounds 2, 1 and 3 (each within the scatter of the next, the first and the last beyond it).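

Putting 4-aminophenyl in place of 3,4-dihydroxyphenyl on a double-bonded chain carbon bound to a double-bonded chain carbon gives a 1.6-fold higher number from compound 1 to compound 3 (0.22 log units; within the scatter) in this assay. Among these compounds, the earlier step altered only one oxygen of the group, whereas this one exchanges the entire group, removing its oxygens and bringing in a nitrogen, and the read-out of compound 3 still does not separate from that of compound 1. No measurement available here accounts for this result.

As far as these compounds go, it remains open whether an unsubstituted phenyl, a 4-hydroxyphenyl or a 4-dimethylaminophenyl at this place would also stay within the scatter of compound 1. Also open, from the compounds shown here alone, is whether a change elsewhere on the shared core would move the number further than any exchange at this place.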